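The source may report more compounds than this note shows. Statements on the series, on what has been measured and on what is new or still open speak of the compounds shown alone.

Of the compounds shown here, three sharing one core have been tested in a functional assay on MCF7 cells (Homo sapiens) for cytotoxicity, read by MTT assay, with a stated time of 72 h; on this read-out lower numbers stand for stronger inhibition and higher numbers for weaker inhibition. Compound 1, `NS(=O)(=O)c1cc(-c2nnc(CN3CCC(Cc4ccccc4)CC3)o2)c(Cl)cc1SCc1ccccc1`, gives 170000 nM in this assay. Compound 2, `NS(=O)(=O)c1cc(-c2nnc(CN3CCN(c4ccc(F)cc4)CC3)o2)c(Cl)cc1SCc1ccccc1`, gives 240000 nM in this assay. Compound 3, `CCOC(=O)c1cn(Cc2nnc(-c3cc(S(N)(=O)=O)c(SCc4ccccc4)cc3Cl)o2)nn1`, gives 150000 nM in this assay. On these numbers compound 3 stands within the usual scatter of both compound 1 and compound 2: its number sits nearest that of compound 1 and furthest from that of compound 2, yet neither gap is wide enough to separate it from either. All three numbers mark only weak inhibition of these cells.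

The next compound, compound 4, is `NS(=O)(=O)c1cc(-c2nnc(/C=C/c3ccc(Br)cc3)o2)c(Cl)cc1SCc1ccccc1`. Going by the values given here, it differs from compound 3 in one place: 2-(4-bromophenyl)ethenyl in place of (4-(ethoxycarbonyl)-1H-1,2,3-triazol-1-yl)methyl on an aromatic carbon None of the measured pairs differs in only one place, so no single-point step is available as a guide. What the three values together show is that the shared core yields weak inhibition whatever group sits on that aromatic carbon, and a change of this kind is therefore expected to move the number by no more than a small amount, with the direction uncertain and most likely within the scatter. The step of a 1.2-fold lower number from compound 3 to compound 4 (0.06 log units; within the scatter) is the expected outcome. Compound 4 is thus estimated at 130000 nM in this assay, with a range from 40000 nM to 400000 nM.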

Compound 4, half-maximal inhibitory concentration: 13000 nM
For compound 4 the middle estimate is 10-fold (1.00 log units) above the measured one; measured number below the stated range.
By their numbers in this assay, from the lowest: compound 4; then compounds 3, 1 and 2 (each within the scatter of the next).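

In this assay, going by these compounds alone, the exchange of (4-(ethoxycarbonyl)-1H-1,2,3-triazol-1-yl)methyl for 2-(4-bromophenyl)ethenyl gives a 12-fold lower number from compound 3 to compound 4 (1.06 log units; beyond the scatter) and so supplies the first single-place comparison, showing that the group on this aromatic carbon of the five-membered ring can move the number beyond the scatter. Several things change together in this one step: a five-membered aromatic ring with 3 hetero atoms and an ester-bearing group leave, while a six-membered aromatic ring of carbon only and a bromine enter, and the hydrogen-bond acceptors of the group go from 5 to 0. Nothing measured here explains the drop or assigns it to any one of these features.

The compounds shown leave open which part of the 2-(4-bromophenyl)ethenyl group carries the step, since they include no version with a hydrogen, a chlorine atom or a methoxy group in place of the bromine, and none with a saturated ethyl link in place of the ethenyl. They also leave open whether a carboxylic acid in place of the ethyl ester on the triazole would change the number of compound 3.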